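A few compounds are considered here, and "the series" means these few. Any claim that something is new, unique, unknown or untested is made for them only; others in the source may bear on it.

Compound 1: `COc1ccc([N+](=O)[O-])cc1CSc1nc2cc(NC(=O)C(C)(C)C)ccc2n1C(C)C`; compound 2: `COc1ccc([N+](=O)[O-])cc1CSc1nc2cc(NC(=O)NC(C)(C)C)ccc2n1C(C)C`; compound 3, not yet measured: `COc1ccc([N+](=O)[O-])cc1CSc1nc2cc(NC(=O)NC(C)C)ccc2n1C(C)C`.

In an assay on isolated protein for inhibition of Gonadotropin-releasing hormone receptor (Rattus norvegicus) (on this read-out lower numbers stand for stronger inhibition and higher numbers for weaker inhibition), compound 2 gives 62 nM. Compound 1 in this assay reaches only > 10000 nM, which is a limit of the assay and not a number. Compound 1 accounts for (the limit of > 10000 nM in this assay, at which 1 of the 2 values shown sits). Going by the values given here, compound 2 therefore holds the only number among the values shown. Among the compounds with values here, the one measured step, an at least 160-fold lower number from compound 1 to compound 2 (2.20 log units; beyond the scatter), is large.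

Compound 3 differs from compound 2 by hydrogen in place of methyl on a saturated chain carbon bound to an amide-type nitrogen and two saturated chain carbons. Within the data shown here, no measured step bears directly on this change: the step from compound 1 to compound 2 exchanges the substituent on the carbonyl carbon rather than trimming the alkyl group on the amide-type nitrogen, so it gives no guide to the size of the present step. Cutting one methyl from the tert-butyl group is a small structural change, and only a modest shift in this assay is expected, most likely toward a higher number. The estimate for compound 3 in this assay is 150 nM, between 40 nM and 600 nM, meaning an expected step of a 2.4-fold higher number from compound 2 to compound 3 (0.38 log units; beyond the scatter).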

Compound 3, half-maximal inhibitory concentration: 280 nM
Estimate against measurement, compound 3: 1.9-fold (0.27 log units) below; low and high end bracket the measured number.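

In this assay, tert-butyl to isopropyl is the only change shown on the alkyl group at this amide-type nitrogen, and the loss of one methyl weakens inhibition beyond the scatter, giving a 4.5-fold higher number from compound 2 to compound 3 (0.65 log units; beyond the scatter). The methyl on this saturated chain carbon therefore contributes measurably, yet the isopropylamino group still keeps much of the advantage over the tert-butyl on the carbonyl carbon of compound 1, with an at least 35-fold lower number from compound 1 to compound 3 (1.55 log units; beyond the scatter), so that advantage does not require the complete (tert-butyl)amino group. The size of this last step is only a bound, since compound 1 stands at a limit of the assay and not at a number: the limit of > 10000 nM in this assay, at which 1 of the 3 values shown sits.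

The compounds shown leave open whether inhibition keeps falling as the alkyl group shrinks further to ethyl or methyl, or whether a cyclic group such as cyclopropyl or cyclobutyl, or a longer chain such as n-butyl, would do better at this nitrogen. They also leave open whether the same methyl matters to the same degree when the nitro or methoxy group on the benzene ring is exchanged for another group, such as a nitrile.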